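One Ring Exchanged on the Four-Membered Ring

A few compounds are considered here, and "the series" means these few. Any claim that something is new, unique, unknown or untested is made for them only; others in the source may bear on it.

Of the compounds shown here, two have been measured in an assay on isolated protein (artery, Oryctolagus cuniculus) with Substance-P receptor (Homo sapiens) as the target; a lower number here means tighter binding, a higher number weaker binding. Compound 1 `O=C1CCC(CCN2CC(N3CCOCC3=O)C2)(c2ccc(Cl)c(Cl)c2)CN1Cc1ccccc1` gives 2.51 nM, and compound 2 `NC(=O)N1CCN(C2CN(CCC3(c4ccc(Cl)c(Cl)c4)CCC(=O)N(CC4CC4)C3)C2)CC1` gives 5.01 nM; compound 2 holds the higher of the two numbers, yet its gap to compound 1 lies within the scatter. Compound 3 `O=C1CCN(C2CN(CCC3(c4ccc(Cl)c(Cl)c4)CCC(=O)N(CC4CC4)C3)C2)CC1` is compound 2 with 4-oxopiperidin-1-yl in place of 4-carbamoylpiperazin-1-yl on a saturated ring carbon. Among the compounds with values here, no measured pair reproduces this change, so the expectation rests on compound 2 alone. The step of a 1.2-fold higher number from compound 2 to compound 3 (0.08 log units; within the scatter) is expected to stay within the scatter, in either direction. Compound 3 is estimated at 6 nM, between 2 nM and 20 nM, in this assay.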

Compound 3, dissociation constant: 1.26 nM
Compound 3: the middle estimate sits 4.8-fold (0.68 log units) above what was measured; measured number outside the range, below it.
By their numbers in this assay, from the lowest: compounds 3, 1 and 2 (each within the scatter of the next, the first and the last beyond it).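

In this assay, placing 4-oxopiperidin-1-yl in place of 4-carbamoylpiperazin-1-yl on this saturated ring carbon gives a 4.0-fold lower number from compound 2 to compound 3 (0.60 log units; beyond the scatter), so the group at this position does affect the number. The entering group has no hydrogen-bond donor and fewer heavy atoms, so neither the carbamoyl group nor the second ring nitrogen is needed for a low number here. Nothing available explains the step. Still open, from the compounds shown here alone, is whether the ring carbonyl matters, which a piperidin-1-yl or 4-hydroxypiperidin-1-yl group on the same carbon would test.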